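This account rests on a few compounds, and the source may have more. Where it says the series, first, only, none or still open, it means among the compounds named here.

Working notes on the series. In a functional assay on HEK293 cells for antagonist activity at transient receptor potential cation channel subfamily V member 1 (Rattus norvegicus) (on this read-out lower numbers stand for stronger inhibition and higher numbers for weaker inhibition), compound 1 `CC(C)c1ccc(NC(=O)N2CCN(c3ncccc3Cl)CC2)cc1` gives 11.5 nM, compound 2 `CCCCc1ccc(NC(=O)N2CCN(c3ncccc3Cl)CC2)cc1` gives 117 nM, and compound 3 `O=C(Nc1ccc(Br)cc1)N1CCN(c2ncccc2Cl)CC1` gives 491 nM, the highest of the three numbers; a 43-fold higher number from compound 1 to compound 3 (1.63 log units; beyond the scatter) and a 4.2-fold higher number from compound 2 to compound 3 (0.62 log units; beyond the scatter) both lie beyond the scatter, as does a 10-fold higher number from compound 1 to compound 2 (1.01 log units; beyond the scatter). Compound 4 `O=C(Nc1ccc([N+](=O)[O-])cc1)N1CCN(c2ncccc2Cl)CC1` differs from compound 3 by nitro in place of bromo on an aromatic carbon. Among the measured compounds shown here, none of the measured steps touches a nitro group: the three steps known all exchange alkyl for alkyl or alkyl for bromo, so no direct bearing on this change exists. For the measured compounds named here, with no precedent, a step within the scatter is expected, that is a 1.2-fold higher number from compound 3 to compound 4 (0.09 log units; within the scatter) in this assay, with wide uncertainty. Compound 4 is therefore estimated at 600 nM, between 150 nM and 2500 nM.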

Compound 4, half-maximal inhibitory concentration: 1110 nM
Compound 4: the middle estimate sits 1.9-fold (0.27 log units) below what was measured, within the range that was stated.
By their numbers in this assay, from the lowest: compound 1; then compound 2; then compound 3; then compound 4.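

Nitro on this aromatic carbon, para to a large group, gives the highest number of the four compounds in this assay (a 2.3-fold higher number from compound 3 to compound 4 (0.35 log units; beyond the scatter)) (a 9.5-fold higher number from compound 2 to compound 4 (0.98 log units; beyond the scatter)) (a 97-fold higher number from compound 1 to compound 4 (1.98 log units; beyond the scatter)). Among these compounds, both groups without carbon, bromo and nitro, stand above both alkyl groups, butyl and isopropyl, and no compound here goes against this order. No measurement at hand accounts for this order.

On these data alone, whether an amine or a carboxylic acid at this position would fall with the alkyl groups or with bromo and nitro stays open. So does whether a tert-butyl group would keep the low number of isopropyl.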